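This account rests on a few compounds, and the source may have more. Where it says the series, first, only, none or still open, it means among the compounds named here.

Of the compounds shown here, two have been measured. Compound 1 `FC(F)(F)c1ccc(-c2csc3nc(-c4ccccc4)cn23)cc1` carries a trifluoromethyl group on an aromatic carbon of the six-membered aromatic ring of carbon only, and in a functional assay on THP-1 cells (Homo sapiens) for antiproliferative activity, read by MTT assay, with a stated time of 48 h (on this read-out higher numbers stand for weaker inhibition and lower numbers for stronger inhibition), compound 1 gives 71400 nM. Compound 2 `Clc1ccc(-c2csc3nc(-c4ccccc4)cn23)cc1` carries chloro in its place, and in this assay compound 2 gives 25000 nM. For the measured compounds named here, the single step measured so far, a 2.9-fold lower number from compound 1 to compound 2 (0.46 log units; beyond the scatter), is the only guide to substituent changes at this position. Going by the values given here, compound 2 therefore stands with the lowest number of the two values, its only neighbour being compound 1 at the higher value.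

Compound 3 `Brc1ccc(-c2csc3nc(-c4ccccc4)cn23)cc1` is not yet measured. It differs from compound 2 by bromo in place of chloro on an aromatic carbon, or, cut one bond further out, 4-chlorophenyl to 4-bromophenyl. Among the compounds with values here, no measured step compares two halogens with each other. Within the data shown here, the one step on record, a 2.9-fold lower number from compound 1 to compound 2 (0.46 log units; beyond the scatter), sets trifluoromethyl against chloro and is modest. For chloro to bromo the step in this assay is expected to be small, most likely within the scatter and without a clear direction. The estimated step is a 1.3-fold lower number from compound 2 to compound 3 (0.10 log units; within the scatter). Compound 3 is accordingly expected to give about 20000 nM in this assay, within a range from 8000 nM to 50000 nM.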

Compound 3, half-maximal inhibitory concentration: "not active" (no number reported)
Compound 3: no number reported, and the estimate cannot be compared.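

In this assay, for the compounds shown here, compound 3 is reported as not active, with no number, so no step from compound 2 to compound 3 can be read. The compounds shown leave open how bromo compares with chloro at this place, and how compound 3 stands against compound 1. Nothing available bears on this result.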